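Compound 2 to compound 4: a step away from the limit

The source may hold more compounds than are shown below. What is called first, only, known or untested is meant among the compounds shown, and "the series" means these compounds.

Values in a functional assay on Huh-7 cells (Homo sapiens) for cytotoxicity, read by MTT assay, with a stated time of 3 days; a lower number here means that less compound is tolerated, a higher number that more compound is tolerated:
compound 1 `OC[C@H]1O[C@@H](n2cnc3c(COc4ccccc4)ncnc32)[C@H](O)[C@@H]1O` > 100000 nM
compound 2 `OC[C@H]1O[C@@H](n2cnc3c(CSc4ccccn4)ncnc32)[C@H](O)[C@@H]1O` > 100000 nM
compound 3 `O=C1CCCN1Cc1ncnc2c1ncn2[C@@H]1O[C@H](CO)[C@@H](O)[C@H]1O` 45000 nM

Compound 2 reads > 100000 nM, a limit of the assay and not a number. Compound 1 reads > 100000 nM, which is likewise a limit. Within the data shown here, the series so far is marked by the limit of > 100000 nM in this assay, at which 2 of the 3 values shown sit. Only compound 3 gives a number, 45000 nM.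

The change to compound 4 `CN(Cc1ccccc1)Cc1ncnc2c1ncn2[C@@H]1O[C@H](CO)[C@@H](O)[C@H]1O` is benzyl(methyl)amino in place of (pyridin-2-yl)sulfanyl on a saturated chain carbon bound to an aromatic carbon.

Among the measured compounds shown here, three measured steps concern this place. The first, a step that the two limits leave unreadable from compound 1 to compound 2, gives no size. The two readable ones are an at least 2.2-fold lower number from compound 1 to compound 3 (0.34 log units; beyond the scatter) and an at least 2.2-fold lower number from compound 2 to compound 3 (0.34 log units; beyond the scatter), both beyond the scatter and both bounded on one side only. The entering group has one six-membered aromatic ring, as the groups of compound 1 and compound 2 do, so the result may well stay at the limit. A modest fall in this assay is still expected, on the precedent of compound 3 with 45000 nM.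

The expected change is an at least 1.6-fold lower number from compound 2 to compound 4 (0.22 log units; that floor lies within the scatter). For compound 4 the estimated value is 60000 nM, with an expected range from 25000 nM to 100000 nM.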

Compound 4, half-maximal cytotoxic concentration: 9000 nM
Estimate against measurement, compound 4: 6.7-fold (0.82 log units) above, outside the stated range (below it).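

In this assay, benzyl(methyl)amino on the saturated chain carbon bound to an aromatic carbon gives the largest readable change at this place, with an at least 11-fold lower number from compound 2 to compound 4 (1.04 log units; beyond the scatter) and an at least 11-fold lower number from compound 1 to compound 4 (1.04 log units; beyond the scatter). Compound 4 also separates from the other compound that gives a number, with a 5.0-fold lower number from compound 3 to compound 4 (0.70 log units; beyond the scatter), so a measurable value here is not tied to 2-oxopyrrolidin-1-yl, and this place can carry a much lower tolerated concentration than compound 3 suggested. Compound 4 keeps one six-membered aromatic ring, as compound 1 and compound 2 do, so such a ring on this chain carbon does not by itself hold a compound at the limit, which still marks part of the series: the limit of > 100000 nM in this assay, at which 2 of the 4 values shown sit.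

The step from compound 1 to compound 2 cannot be read, since both values are limits, so phenoxy and (pyridin-2-yl)sulfanyl stay unranked. Nor do the compounds shown tell whether the fall follows the amine nitrogen, its methyl or its benzyl part, a question that a dimethylamino group or a benzylamino group carrying no methyl at the same place would address.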